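The compounds below may be only part of what the source reports. "The series", "measured", "known", "first", "only" and "open" are said of these compounds alone.

Measured compounds:
compound 1 `CCCOC(=O)Nc1ccc([Se]C#N)cc1` gives 68800 nM
compound 2 `CCCCOC(=O)Nc1ccc([Se]C#N)cc1` gives 63500 nM

Both numbers come from a functional assay on CCRF-CEM cells (Homo sapiens) for cytotoxicity, read by MTT assay, with a stated time of 72 h; a higher number here means that more compound is tolerated, a lower number that less compound is tolerated. Among the measured compounds shown here, compound 2 stands next to compound 1, and the only step measured, a 1.1-fold lower number from compound 1 to compound 2 (0.03 log units; within the scatter), lies within the scatter, so the two compounds cannot be told apart on these numbers.

Compound 3 `CC(C)COC(=O)Nc1ccc([Se]C#N)cc1` has not been measured. It differs from compound 2 by isopropyl in place of propyl on a saturated chain carbon bound to an oxygen next to a carbonyl group. For the measured compounds named here, no measured step bears directly on this change; the one step known, a 1.1-fold lower number from compound 1 to compound 2 (0.03 log units; within the scatter), concerns a different change on the same chain and was itself within the scatter. Going by the values given here, the only guidance is therefore that a small alteration of this chain did not move the number. On that basis compound 3 is expected to give a number within the scatter of compound 2, with the expected step of a 1.0-fold lower number from compound 2 to compound 3 (0.01 log units; within the scatter). The estimate for compound 3 in this assay is 62000 nM, with a range from 30000 nM to 125000 nM.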

Compound 3, concentration lethal to 50% of the cells: 68700 nM
Compound 3: the middle estimate sits 1.1-fold (0.04 log units) below what was measured; the measured number falls inside the stated range.
By their numbers in this assay, from the lowest: compounds 2, 3 and 1 (each within the scatter of the next).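

In this assay, going from the butyl chain to the isobutyl chain, with propyl giving way to isopropyl on a saturated chain carbon bound to an oxygen next to a carbonyl group, gave a 1.1-fold higher number from compound 2 to compound 3 (0.03 log units; within the scatter), so this rearrangement of the same atoms left the number within the scatter. The added methyl on a saturated chain carbon bound to two saturated chain carbons gave a 1.0-fold lower number from compound 1 to compound 3 (0.00 log units; within the scatter), which means that this branching, like the lengthening seen earlier, leaves compound 1, compound 2 and compound 3 indistinguishable. Nothing further is available that bears on this result.

Whether any group at this place can move the number remains open, since a much longer chain, a benzyl group or an amine is not among the compounds shown. On these data alone, all three also share the same core, so what changes elsewhere on it would do is unknown.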